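The compounds below may be only part of what the source reports. "The series", "measured", "known", "first", "only" and "open" are said of these compounds alone.

Working notes on the series in an ADME assay on microsomes from liver (Homo sapiens) for metabolic stability, read by LC-MS, using NADPH, with a stated time of 15 min, tested at 1 uM; on this read-out higher numbers stand for fast clearance and lower numbers for slow clearance. Compound 1 `Cc1nc(C)n(CC(=O)N2CCN(c3sc(C(F)(F)F)nc3-c3nc4ccc(C5CCN(C)CC5)cc4[nH]3)C[C@H]2C)n1` gives 27 mL.min-1.g-1 in this assay. Compound 2 `C[C@@H]1CN(c2sc(C(F)(F)F)nc2-c2nc3ccccc3[nH]2)CCN1C(=O)Cn1cnc2cccnc21` gives 89 mL.min-1.g-1 in this assay. Compound 3 `Cc1nc(C)n(CC(=O)N2CCN(c3sc(C(F)(F)F)nc3-c3nc4c(F)cccc4[nH]3)C[C@H]2C)n1` gives 24 mL.min-1.g-1 in this assay, the lowest of the three numbers; compound 1 is its nearest neighbour, with a number higher by an amount that stays within the scatter, and compound 2 its furthest, with a number higher by an amount that goes beyond the scatter.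

Compound 4 `Cc1nc(C)n(CC(=O)N2CCN(c3sc(C(F)(F)F)nc3-c3nc4ccccc4[nH]3)C[C@H]2C)n1` has not yet been run. It differs from compound 3 in one place: hydrogen in place of fluoro on an aromatic carbon, that is, 4-fluoro-1H-benzimidazol-2-yl becomes 1H-benzimidazol-2-yl. For the measured compounds named here, no measured pair in the set carries this exact difference alone. Compound 2 also bears 1H-benzimidazol-2-yl and gives the highest number of the three, but it differs from compound 4 in the amide-linked heteroaryl as well, so its number cannot be read as a step for this change.

The step of a 1.3-fold higher number from compound 3 to compound 4 (0.12 log units; within the scatter) is expected to be small, upward if anything, and within the scatter. Compound 4 is estimated at 32 mL.min-1.g-1 in this assay, with a range from 15 mL.min-1.g-1 to 70 mL.min-1.g-1.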

Compound 4, intrinsic clearance in microsomes in the Homo sapiens assay: 30 mL.min-1.g-1
Beside the measured number, compound 4's estimate is 1.1-fold (0.03 log units) above it, and the stated range covers the measured number.
By their numbers in the Homo sapiens assay, from the lowest: compounds 3, 1 and 4 (each within the scatter of the next); then compound 2.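

For the compounds shown here, in the Homo sapiens assay the exchange of fluoro for hydrogen on this aromatic carbon now has a direct reading (a 1.3-fold higher number from compound 3 to compound 4 (0.10 log units; within the scatter)), and it resolves no change; the same holds for hydrogen in place of 1-methylpiperidin-4-yl (a 1.1-fold higher number from compound 1 to compound 4 (0.05 log units; within the scatter)), whereas the exchange of the amide-linked heteroaryl gives the only one of these steps beyond the scatter (a 3.0-fold lower number from compound 2 to compound 4 (0.47 log units; beyond the scatter)). In a physicochemical assay for solubility, in simulated intestinal fluid (a higher number here means a more soluble compound, a lower number a less soluble compound), compound 3 gives 750 ug/mL as a measured number. In the same assay compound 4 gives > 850 ug/mL, which is a limit of the assay and not a number: the limit of > 850 ug/mL in the physicochemical assay, at which 1 of the 2 values shown sits.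

On these data alone, the size of the step between these two compounds in the physicochemical assay cannot be read from a limit, so the effect of this change on that read-out stays open. As far as these compounds go, whether a different group on this aromatic carbon, such as chloro, methoxy or a nitrile, would give a step beyond the scatter in the Homo sapiens assay also stays open.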